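From 2,4-dimethoxyphenyl to anilino on the shared core

The source may hold more compounds than are shown below. What is called first, only, known or untested is meant among the compounds shown, and "the series" means these compounds.

- compound 1 `COc1cc(C(=O)c2sc3ccccc3c2-c2ccc(Cl)cc2)cc(OC)c1OC`: 3700 nM
- compound 2 `COc1ccc(-c2c(C(=O)c3cc(OC)c(OC)c(OC)c3)sc3ccccc23)cc1`: 1600 nM
- compound 3 `COc1ccc(-c2c(C(=O)c3cc(OC)c(OC)c(OC)c3)sc3ccccc23)c(OC)c1`: 4000 nM
- compound 4 `COc1cc(C(=O)c2sc3ccccc3c2Nc2ccccc2)cc(OC)c1OC`: not yet measured

In a functional assay on Jurkat cells (Homo sapiens) for antiproliferative activity, read by MTT assay, with a stated time of 72 h (on this read-out lower numbers stand for stronger inhibition and higher numbers for weaker inhibition), compound 3 gives 4000 nM. That number is level with one of the other two measured compounds and clearly apart from the other: a 1.1-fold higher number from compound 1 to compound 3 (0.03 log units; within the scatter), and a 2.5-fold higher number from compound 2 to compound 3 (0.40 log units; beyond the scatter).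

The next structure swaps a whole group, with anilino in place of 2,4-dimethoxyphenyl on an aromatic carbon of the five-membered aromatic ring with 1 sulfur: anilino in place of 2,4-dimethoxyphenyl on an aromatic carbon. Within the data shown here, no measured compound carries anilino, so no step tests this swap directly. The closest evidence comes from smaller changes on the group at that place: a 2.3-fold lower number from compound 1 to compound 2 (0.36 log units; beyond the scatter), and the step back up already shown, a 2.5-fold higher number from compound 2 to compound 3 (0.40 log units; beyond the scatter). Both are modest, and neither gives a direction for the new group. No step beyond the scatter is therefore expected in this assay, though with wide uncertainty.

The expected move is a 1.3-fold lower number from compound 3 to compound 4 (0.12 log units; within the scatter). For compound 4 the estimated value is 3000 nM, with an expected range from 800 nM to 10000 nM.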

Compound 4, half-maximal inhibitory concentration: 1600 nM
Compound 4: middle estimate off by 1.9-fold (0.27 log units), on the high side; the range from low to high includes it.
By their numbers in this assay, from the lowest: compounds 2 and 4 (each within the scatter of the next); then compounds 1 and 3 (each within the scatter of the next).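

This position on the five-membered ring also tolerates anilino, which brings nitrogen and a hydrogen-bond donor that the earlier groups lack, so activity here in this assay does not depend on a phenyl ring attached directly to the shared core. The new group gives a 2.5-fold lower number from compound 3 to compound 4 (0.40 log units; beyond the scatter) and a 2.3-fold lower number from compound 1 to compound 4 (0.36 log units; beyond the scatter), both modest steps, while the comparison with 4-methoxyphenyl shows no change at the digits printed from compound 2 to compound 4 (within the scatter), so anilino matches the better of the earlier groups without going past it. No available evidence bears on what lies behind these steps.

The compounds shown leave open whether the hydrogen on the anilino nitrogen matters, which N-methylanilino could test. Also open, as far as these compounds go, is whether a methoxy on the anilino ring would shift the number as the methoxy groups did on the phenyl ring.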